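Lipophilicity notes: amine swap at the benzylic position

This account rests on a few compounds, and the source may have more. Where it says the series, first, only, none or still open, it means among the compounds named here.

Measured so far:
compound 1, `CC1CCCN(Cc2c(-c3nnc(SC(C)C)n3-c3ccccc3)n(C)c3ccccc23)C1`: 6.03
compound 2, `COc1ccc(CNCc2c(-c3nnc(SC(C)C)n3-c3ccccc3)n(C)c3ccc(F)cc23)cc1`: 6.42
compound 3, `COCCNCc1c(-c2nnc(SC(C)C)n2-c2ccccc2)n(C)c2ccccc12`: 4.36

In a physicochemical assay for lipophilicity (a lower number here means a more polar compound, a higher number a more lipophilic compound), compound 1 gives 6.03 and stands second highest of the three numbers; compound 2 lies nearest, its value 6.42 a number beyond the scatter higher, while compound 3 lies furthest with 4.36. For the measured compounds named here, the one step that cuts through a single change is a number 1.67 log units lower from compound 1 to compound 3 (beyond the scatter), a large drop when the tertiary cyclic amine gives way to a small open chain with an ether oxygen.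

Compound 4, `CC(C)Sc1nnc(-c2c(CNc3nc4ccccc4[nH]3)c3ccccc3n2C)n1-c1ccccc1`, is the next case at the same place: (1H-benzimidazol-2-yl)amino in place of 3-methylpiperidin-1-yl on a saturated chain carbon bound to an aromatic carbon.

Going by the values given here, the step from compound 1 to compound 3 is the only comparison that bears on this, and it shows that exchanging the 3-methylpiperidin-1-yl group can move this assay by a large amount. The incoming (1H-benzimidazol-2-yl)amino group, however, brings two aromatic rings and more heavy atoms than the (2-methoxyethyl)amino group did, so a smaller drop is expected, in the same direction. Compound 4 is therefore expected to give 5.4, within 4.6 to 6.3, which means an expected step of a number 0.63 log units lower from compound 1 to compound 4 (beyond the scatter).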

Compound 4, partition coefficient: 5.94
Beside the measured number, compound 4's estimate is 0.54 log units below it; the measured number falls inside the stated range.
By their numbers in this assay, from the lowest: compound 3; then compounds 4 and 1 (each within the scatter of the next); then compound 2.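

In this assay, (1H-benzimidazol-2-yl)amino in place of 3-methylpiperidin-1-yl gives a number 0.09 log units lower from compound 1 to compound 4 (within the scatter), so a replacement on this saturated chain carbon bound to an aromatic carbon need not shift the number, even when the entering group has more heavy atoms, two aromatic rings and more hydrogen-bond donors than the group it replaces. With 1H-benzimidazol-2-yl in place of 2-methoxyethyl on the amine nitrogen, the step is a number 1.58 log units higher from compound 3 to compound 4 (beyond the scatter), which shows that the outcome depends on the group carried by that nitrogen and that the large step to compound 3 is not common to every replacement of 3-methylpiperidin-1-yl. No measurement is available to explain why these two entering groups behave so differently.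

The compounds shown leave open which part of the (1H-benzimidazol-2-yl)amino group sets its number, the fused aromatic rings or the added nitrogens. A phenylamino group would test the aromatic ring without those nitrogens, and a morpholin-4-yl group would place an ether oxygen in a ring like that of compound 1, testing whether the open 2-methoxyethyl chain is needed for a large step.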